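This account rests on a few compounds, and the source may have more. Where it says the series, first, only, none or still open, it means among the compounds named here.

Compound 1 `CCCOC(=O)CCC(=O)N1CCN(CCCOc2cc3c(Nc4ccc(F)c(Cl)c4)ncnc3cc2OC)CC1`: 80.9%
Compound 2 `CCCCCOC(=O)CCC(=O)N1CCN(CCCOc2cc3c(Nc4ccc(F)c(Cl)c4)ncnc3cc2OC)CC1`: 63.6%
Compound 3 `CCCCCCCCCCOC(=O)CCC(=O)N1CCN(CCCOc2cc3c(Nc4ccc(F)c(Cl)c4)ncnc3cc2OC)CC1`: 15.5%

Three compounds share one core and differ only in the group attached to the oxygen next to a carbonyl group. In a functional assay on A549 cells (Homo sapiens) for cytotoxicity, read by MTT assay, with a stated time of 24 h, tested at 40 uM (on this read-out higher numbers stand for a weaker effect at the one concentration tested and lower numbers for a stronger effect), compound 1 gives 80.9%, compound 2 gives 63.6%, and compound 3 gives 15.5%, the lowest of the three numbers and therefore the strongest effect seen here. Each lengthening lowered the number: a number 17.3 percentage points lower from compound 1 to compound 2 (beyond the scatter), a number 48.1 percentage points lower from compound 2 to compound 3 (beyond the scatter), and overall a number 65.4 percentage points lower from compound 1 to compound 3 (beyond the scatter). Compound 4 `CCCCCCCCCCCCCCCCCCOC(=O)CCC(=O)N1CCN(CCCOc2cc3c(Nc4ccc(F)c(Cl)c4)ncnc3cc2OC)CC1` carries the same kind of change once more: octyl in place of hydrogen on a saturated chain carbon, ten or more bonds along the chain from an oxygen next to a carbonyl group. All three measured steps ran the same way, the longer additions giving the larger drops, so a further fall is expected, though compound 3 already leaves little room before the percentage reaches zero. Compound 4 is estimated at 8%, between 0% and 25%, an expected step of a number 7.5 percentage points lower from compound 3 to compound 4 (within the scatter).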

Compound 4, a percentage reported as activity, at one concentration (the size of the read-out at that concentration, not a potency): 91%
Beside the measured number, compound 4's estimate is 83 percentage points below it, and the stated range ends below it.
By their numbers in this assay, from the lowest: compound 3; then compound 2; then compound 1; then compound 4.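

In this assay, the run of falling numbers stops: octyl in place of hydrogen on a saturated chain carbon gives a number 75.5 percentage points higher from compound 3 to compound 4 (beyond the scatter). Lengthening at this position therefore does not work in one direction only, and compound 4 goes against the trend of the earlier compounds. No available evidence explains this reversal. On these data alone, what stays open is how the number changes from the chain of compound 3 to that of compound 4, which a dodecyl or tetradecyl chain would help to show.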